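A Repeated Methoxy-to-Trifluoromethyl Swap on Two Cores

A few compounds are considered here, and "the series" means these few. Any claim that something is new, unique, unknown or untested is made for them only; others in the source may bear on it.

Compound 1 `COc1ccc(C(=O)NC(CCN(C)C)c2ccc(Cl)cc2)cc1` and compound 3 `COc1ccc(NC(=O)NC(CCN(C)C)c2ccc(Cl)cc2)cc1` carry the same side chain on different cores; the difference between the two cores is not broken down here. In an assay on NIH3T3 cells with Urotensin-2 receptor (Homo sapiens) as the target (a higher number here means a larger maximal response, a lower number a smaller maximal response), compound 1 gives 162%, and compound 3 gives 195%, the highest of the three measured numbers. Compound 2 `CN(C)CCC(NC(=O)c1ccc(C(F)(F)F)cc1)c1ccc(Cl)cc1` differs from compound 1 by trifluoromethyl in place of methoxy on an aromatic carbon, and in this assay compound 2 gives 115%, so that the change made a number 47 percentage points lower from compound 1 to compound 2 (beyond the scatter). Compound 4 `CN(C)CCC(NC(=O)Nc1ccc(C(F)(F)F)cc1)c1ccc(Cl)cc1` carries the same change on the core of compound 3, namely (trifluoromethyl in place of methoxy on an aromatic carbon), at a place described in the same words in both pairs. Its value in this assay is not yet known. The expected step is a number 47 percentage points lower from compound 3 to compound 4 (beyond the scatter), resting on the observation that the same change made a number 47 percentage points lower from compound 1 to compound 2 (beyond the scatter) on the core of compound 1. Compound 4 is therefore expected to reach about 148% in this assay, most likely between 110% and 185%.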

Compound 4, largest response reached (reported as efficacy), in percent of the reference or control that the assay uses: 105%
Compound 4: middle estimate off by 43 percentage points, on the high side; the whole stated range lies above it.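

In this assay, trifluoromethyl in place of methoxy again gives a lower number, with a number 90 percentage points lower from compound 3 to compound 4 (beyond the scatter), so the direction of the change holds on both cores shown. The size of the step does not carry over from one core to the other: the same change on two cores in this assay, a number 47 percentage points lower (beyond the scatter) from compound 1 to compound 2 and a number 90 percentage points lower (beyond the scatter) from compound 3 to compound 4, 43 percentage points apart, beyond the scatter of two such steps. For the compounds shown here, with only one pair on each core, this shows that the size of the step differed between these two cores, but it does not show how the change would behave on a third core, nor what about the cores accounts for the gap.

The compounds shown compare only methoxy and trifluoromethyl at this place, so it remains open whether a nitrile or a carboxylic acid there would give a similar gap between the two cores. From the compounds shown here alone, it also remains open whether the gap would persist with a longer chain or a different amine in place of the dimethylamino end of the side chain.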